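Ester variation on the shared core: compound 3 to compound 4

This account rests on a few compounds, and the source may have more. Where it says the series, first, only, none or still open, it means among the compounds named here.

Going by the values given here, compound 3 `CC1=C(C(=O)OC2CCCC2)C(c2ccoc2)NC(=O)N1` gives 6% in an assay on membranes from CHO cells for displacement of a labelled ligand from adenosine receptor A1 (Homo sapiens), read by scintillation counting, with a stated time of 60 min, tested at 1 uM (on this read-out lower numbers stand for less inhibition and higher numbers for more inhibition at the one concentration tested (going by the name of the read-out)), the lowest of the three numbers so far. Compound 1 `COC(=O)C1=C(C)NC(=O)NC1c1ccoc1` gives 8%, with a number 2 percentage points lower from compound 1 to compound 3 (within the scatter). Compound 2 `CC1=C(C(=O)OCc2ccccc2)C(c2ccoc2)NC(=O)N1` gives 41%, with a number 35 percentage points lower from compound 2 to compound 3 (beyond the scatter). The next member, compound 4 `CC1=C(C(=O)OCC2CC2)C(c2ccoc2)NC(=O)N1`, differs from compound 3 by cyclopropylmethyl in place of cyclopentyl on an oxygen next to a carbonyl group. Among the compounds with values here, two steps bear on this: the exchange of methyl for cyclopentyl stayed within the scatter, a number 2 percentage points lower from compound 1 to compound 3 (within the scatter), while only the benzyl ester moved the read-out, a number 35 percentage points lower from compound 2 to compound 3 (beyond the scatter). Cyclopropylmethyl, like methyl and cyclopentyl, carries no phenyl, so no step beyond the scatter is expected, a number 2 percentage points higher from compound 3 to compound 4 (within the scatter). Compound 4 is therefore estimated at 8% in this assay, expected between -5% and 22%.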

Compound 4, a percentage reported as inhibition, at one concentration (the size of the read-out at that concentration, not a potency): 29%
Beside the measured number, compound 4's estimate is 21 percentage points below it; measured number outside the range, above it.
By their numbers in this assay, from the lowest: compounds 3 and 1 (each within the scatter of the next); then compound 4; then compound 2.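

Going by these compounds alone, on the oxygen next to a carbonyl group, a phenyl is no longer the only change that moves the read-out in this assay: cyclopropylmethyl gives a number 23 percentage points higher from compound 3 to compound 4 (beyond the scatter) and a number 21 percentage points higher from compound 1 to compound 4 (beyond the scatter). Benzyl still keeps the lead, with a number 12 percentage points lower from compound 2 to compound 4 (beyond the scatter), so the two ring-bearing groups cyclopentyl and cyclopropylmethyl do not behave alike here. No measurement at hand explains this difference.

Open, as far as these compounds go, is whether an ethyl, a longer chain or a chain ending in an amine on this oxygen would follow cyclopropylmethyl or cyclopentyl. From the compounds shown here alone, whether these steps carry over to other cores also remains open.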